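Dropping the Hydroxy Group of Compound 1

The source may report more compounds than this note shows. Statements on the series, on what has been measured and on what is new or still open speak of the compounds shown alone.

Measured compounds and their inhibition at one concentration:
compound 1 `O=C(c1ccc(F)c(O)c1)c1ccc2cc(O)ccc2n1` gives 20%
compound 2 `C=C(c1ccc(F)c(O)c1)c1cccc(-c2cccc(O)c2F)n1` gives 88%
compound 3 `CN(c1ccc(F)c(O)c1)c1cccc(-c2cccc(O)c2F)n1` gives 99%

All three were tested in an assay for inhibition of 17-beta-hydroxysteroid dehydrogenase type 1 (Homo sapiens), read by HPLC, with a stated time of 10 min, tested at 1 uM; on this read-out lower numbers stand for less inhibition and higher numbers for more inhibition at the one concentration tested (going by the name of the read-out). Compound 1 stands lowest of the three numbers: compound 2 lies well above it and compound 3 lies further above still, both gaps beyond the usual scatter of this kind of measurement. Compound 1 therefore shows only modest inhibition at the concentration tested.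

Compound 4 `O=C(c1ccc(F)c(O)c1)c1ccc2ccccc2n1` has not yet been measured. It differs from compound 1 in one place: hydrogen in place of hydroxy on an aromatic carbon. Among the measured compounds shown here, no measured pair in this set shows the effect of that change, so the expectation must rest on where compound 1 already sits.

Since compound 1 gives 20%, there is little room for the number to fall, and the expected step of a number 10 percentage points lower from compound 1 to compound 4 (within the scatter) is a small decrease that would lie within the scatter. Compound 4 is estimated to give 10%, with a likely range from 0% to 28%.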

Compound 4, a percentage reported as inhibition, at one concentration (the size of the read-out at that concentration, not a potency): 6%
For compound 4 the middle estimate is 4 percentage points above the measured one, and the stated range covers the measured number.
By their numbers in this assay, from the lowest: compound 4; then compound 1; then compound 2; then compound 3.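

In this assay, among the compounds shown here, putting hydrogen in place of hydroxy on this aromatic carbon of the fused ring system gives a number 14 percentage points lower from compound 1 to compound 4 (beyond the scatter) and offers the only direct reading of this change in the set. Compound 4 gives 6% without the hydroxy group, so the group counts for something at this position, although the step is modest and starts from an already low number. No supporting measurement shows why removing the hydroxy group lowers the number.

Going by these compounds, it remains open whether a methoxy group, an amine or a carboxylic acid at the same position would lift inhibition above that of compound 1 or lower it. On these data alone, it is also open whether removing a hydroxy group from compound 2 or compound 3 would produce a step of similar size.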